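Cyclobutyl in place of cyclohexyl on the shared core

A few compounds are considered here, and "the series" means these few. Any claim that something is new, unique, unknown or untested is made for them only; others in the source may bear on it.

Measured in a functional assay on U-937 cells (Homo sapiens), read by cAMP accumulation; a higher number here means that more compound is needed for the effect, a lower number that less compound is needed:
- compound 1 `CCc1nn(-c2ccc(F)cc2)c2c1CCN(c1ccccc1)C2=O`: 880 nM
- compound 2 `CCc1nn(C2CCCC2)c2c1CCN(c1cccc(OC)c1)C2=O`: 330 nM
- compound 3 `CCc1nn(C2CCCCC2)c2c1CCN(c1cccc(OC)c1)C2=O`: 980 nM

In this assay compound 3 gives 980 nM, which lies within the scatter of compound 1 at 880 nM. Compound 2 gives a clearly lower number, 330 nM.

The next compound is compound 4 `CCc1nn(C2CCC2)c2c1CCN(c1cccc(OC)c1)C2=O`, not yet measured, with this change from compound 3: cyclobutyl in place of cyclohexyl on an aromatic nitrogen.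

Among the compounds with values here, only one measured step changes the same group at the same place: a 3.0-fold higher number from compound 2 to compound 3 (0.47 log units; beyond the scatter). Within the data shown here, compound 1 differs from the others in more than one place and offers no such step. Among the measured compounds shown here, no compound with a ring smaller than cyclopentyl has been measured, so whether the number keeps falling or turns back up is open. A step of similar or smaller size towards a lower number therefore seems most likely.

In this assay the expected change is a 2.0-fold lower number from compound 3 to compound 4 (0.29 log units; within the scatter). For compound 4 the estimated value is 500 nM, with an expected range of 210 nM to 1200 nM.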

Compound 4, half-maximal effective concentration: 520 nM
Estimate against measurement, compound 4: 1.0-fold (0.02 log units) below; the range from low to high includes it.
By their numbers in this assay, from the lowest: compounds 2, 4, 1 and 3 (each within the scatter of the next, the first and the last beyond it).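

In this assay, cyclobutyl in place of cyclohexyl on the aromatic nitrogen gives a 1.9-fold lower number from compound 3 to compound 4 (0.28 log units; within the scatter), while cyclobutyl in place of cyclopentyl gives a 1.6-fold higher number from compound 2 to compound 4 (0.20 log units; within the scatter). Although a 3.0-fold higher number from compound 2 to compound 3 (0.47 log units; beyond the scatter) separates the five- and six-membered rings, neither of them can be separated from the four-membered ring, so this position accepts a ring smaller than cyclopentyl and the three compounds show no clear trend with ring size. No supporting data are available to explain this result.

As far as these compounds go, whether cyclopropyl, an open chain such as isopropyl, or a ring carrying an amine would stay in this range remains open. From the compounds shown here alone, it is also open whether these steps would hold if the methoxy group on the shared core were replaced by a hydroxyl group or a fluorine.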